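The source may report more compounds than this note shows. Statements on the series, on what has been measured and on what is new or still open speak of the compounds shown alone.

Compound 2 `COc1ccc(N/C=C\C(=O)c2nc(-c3ccc(C(F)(F)F)cc3)n3ccccc23)cc1OC` was tested in a functional assay on A549 cells (Homo sapiens) for cytotoxicity, read by MTT assay, with a stated time of 48 h; a lower number here means a stronger inhibitor, a higher number a weaker inhibitor. For compound 2 this assay reports only a limit, > 30000 nM, and not a number. That limit is the limit of > 30000 nM in this assay, at which 1 of the 3 values shown sits. Compound 1 `COc1ccc(-c2nc(C(=O)/C=C\Nc3ccc4[nH]ccc4c3)c3ccccn23)cc1` gives 4800 nM in this assay. Compound 3 `COc1ccc(N/C=C\C(=O)c2nc(-c3ccc(OC)cc3)n3ccccc23)cc1` has no result in this assay, recorded as "not determined" (no result reported).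

Compound 4 `O=C(/C=C\Nc1ccc2[nH]ccc2c1)c1nc(-c2ccc(C(F)(F)F)cc2)n2ccccc12` differs from compound 2 in a single place: 1H-indol-5-yl in place of 3,4-dimethoxyphenyl on an amine nitrogen. Within the data shown here, no two of the measured compounds differ in only one place, so no measured step shows how large such a change is here. Among the measured compounds shown here, the (1H-indol-5-yl)amino group that enters is the one carried by compound 1, whose value of 4800 nM is the only number reported in this assay. On that basis the step is expected to move toward stronger inhibition by more than the usual scatter, as an at least 3.7-fold lower number from compound 2 to compound 4 (0.57 log units; beyond the scatter). Compound 4 is therefore estimated at 8000 nM in this assay, with a range from 2500 nM to 30000 nM.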

Compound 4, half-maximal inhibitory concentration: 5190 nM
The estimate for compound 4 lay 1.5-fold (0.19 log units) above the measured number; the range from low to high includes it.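

In this assay, 1H-indol-5-yl in place of 3,4-dimethoxyphenyl on the amine nitrogen gives an at least 5.7-fold lower number from compound 2 to compound 4 (0.76 log units; beyond the scatter), which shows that this position can matter in this series. On these data alone, the true size of that step stays unknown, since compound 2 carries a limit of the assay and not a number: the limit of > 30000 nM in this assay, at which 1 of the 4 values shown sits. With 1H-indol-5-yl in place, the exchange of methoxy for trifluoromethyl on an aromatic carbon gives a 1.1-fold higher number from compound 1 to compound 4 (0.03 log units; within the scatter), so compound 1 and compound 4 cannot be told apart in this test.

Compound 3 has no reported result and adds nothing to this comparison. As far as these compounds go, whether a plain phenyl or a carboxylic acid on that amine nitrogen would match compound 4 stays open, as does whether chlorine in place of trifluoromethyl would also leave the number within the scatter.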